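Swapping furan for thiophene on a dihydropyrimidinone ester

The source may hold more compounds than are shown below. What is called first, only, known or untested is meant among the compounds shown, and "the series" means these compounds.

Compound 1 `CC1=C(C(=O)OC(C)C)C(c2ccoc2)NC(=O)N1C`: 37%
Compound 2 `CC1=C(C(=O)OC(C)(C)C)C(c2ccoc2)NC(=O)N1C`: 16%

In an assay on membranes from HEK293 cells for displacement of a labelled ligand from adenosine receptor A2b (Homo sapiens), read by scintillation counting, with a stated time of 30 min, tested at 1 uM (a higher number here means more inhibition at the concentration tested (going by the name of the read-out), a lower number less inhibition), compound 2 gives the lower of the two measured numbers, the step being a number 21 percentage points lower from compound 1 to compound 2 (beyond the scatter). Compound 3 `CC1=C(C(=O)OC(C)(C)C)C(c2ccsc2)NC(=O)N1C` differs from compound 2 by thiophen-3-yl in place of furan-3-yl on a saturated ring carbon. Among the compounds with values here, no measured step here concerns this ring swap; the only step recorded changes the ester, not the five-membered ring, so it offers no guidance. Compound 3 is therefore expected to stay close to compound 2, with a number 4 percentage points higher from compound 2 to compound 3 (within the scatter) expected to lie within the scatter. The estimate for compound 3 is 20%, in the range 5% to 40%.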

Compound 3, a percentage reported as inhibition, at one concentration (the size of the read-out at that concentration, not a potency): 35%
For compound 3 the middle estimate is 15 percentage points below the measured one, within the range that was stated.
By their numbers in this assay, from the lowest: compound 2; then compounds 3 and 1 (each within the scatter of the next).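

In this assay thiophen-3-yl in place of furan-3-yl on the saturated ring carbon gives a number 19 percentage points higher from compound 2 to compound 3 (beyond the scatter) and so the choice of ring at this position does affect the read-out. The two groups have the same count of heavy atoms and differ by one ring atom, sulfur for oxygen, so a change this small is enough to move the number here. Nothing measured explains why this swap has this effect.

On these data alone, whether the same swap would raise the number with the ester of compound 1 remains open. So does how a phenyl or pyridin-3-yl ring would read at this position.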